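A few compounds are considered here, and "the series" means these few. Any claim that something is new, unique, unknown or untested is made for them only; others in the source may bear on it.

Compound 2 `O=C(C1=C(Nc2ccc(I)cc2)C(=O)N(CCCn2ccnc2)C1c1ccc(Br)cc1)c1ccccc1` is one of two compounds tested in a functional assay on U2OS cells (Homo sapiens) for antiproliferative activity, read by MTT assay, with a stated time of 72 h; a higher number here means a weaker inhibitor, a lower number a stronger inhibitor; in that assay compound 2 gives 12000 nM, the highest of the two numbers, while compound 1 `CCCCCOC1=C(C(=O)c2ccccc2)C(c2ccc(Br)cc2)N(CCCn2ccnc2)C1=O` gives 9140 nM, and the gap between them lies within the scatter. For the measured compounds named here, the only measured step, a 1.3-fold higher number from compound 1 to compound 2 (0.12 log units; within the scatter), touches the same part of the shared core but is a different kind of exchange. Compound 3 `O=C(C1=C(Nc2cccc(Br)c2)C(=O)N(CCCn2ccnc2)C1c1ccc(Br)cc1)c1ccccc1` differs from compound 2 by 3-bromophenyl in place of 4-iodophenyl on an amine nitrogen. Going by the values given here, no measured step trades one such phenyl group for another at that nitrogen, so the expectation rests on the one step that concerns this part of the molecule, which stayed within the scatter. The step from compound 2 to compound 3 is therefore expected to be no change at the digits printed from compound 2 to compound 3 (within the scatter), nothing beyond the scatter. Compound 3 is expected to give 12000 nM in this assay, within a range from 5000 nM to 30000 nM.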

Compound 3, half-maximal inhibitory concentration: 11900 nM
Compound 3: the middle estimate sits 1.0-fold (0.00 log units) above what was measured; low and high end bracket the measured number.
By their numbers in this assay, from the lowest: compounds 1, 3 and 2 (each within the scatter of the next).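

In this assay, for the compounds shown here, the step of a 1.0-fold lower number from compound 2 to compound 3 (0.00 log units; within the scatter) is the first measured trade of one phenyl group for another on the amine nitrogen, and it stays within the scatter, so 3-bromophenyl and 4-iodophenyl cannot be told apart here. The step of a 1.3-fold higher number from compound 1 to compound 3 (0.11 log units; within the scatter) also stays within the scatter, so (3-bromophenyl)amino, like (4-iodophenyl)amino, cannot be told from pentyloxy on the double-bonded ring carbon. Nothing measured here offers an explanation for these results.

The two phenyl groups differ in both the halogen and its printed ring number, so 4-bromophenyl or 3-iodophenyl would be needed to read those changes separately. From the compounds shown here alone, it also stays open whether a phenyl group carrying a carboxylic acid, or a plain pentyl chain, on that nitrogen would move the number beyond the scatter.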